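Adding a Chloro Group to the Stronger Urea Compound

This account rests on a few compounds, and the source may have more. Where it says the series, first, only, none or still open, it means among the compounds named here.

Measured compounds:
Compound 1 `COc1cc2cc(Oc3ccc(NC(=O)Nc4ccc(C(F)(F)F)cc4)cc3)c(C)nc2cc1OC` gives 56.1% in a functional assay on ACHN cells (Homo sapiens) for inhibition, read by sulforhodamine B assay, with a stated time of 48 h, tested at 10 uM; on this read-out lower numbers stand for a stronger effect and higher numbers for a weaker effect at the one concentration tested.
Compound 2 `COc1cc2cc(Oc3ccc(NC(=O)Nc4cccc(C(F)(F)F)c4)cc3)c(C)nc2cc1OC` gives 11.2% in this assay.

Among the measured compounds shown here, of the two numbers, compound 2 holds the lowest, which here means the stronger effect; the only other number, from compound 1, sits well above it, and the step of a number 44.9 percentage points lower from compound 1 to compound 2 (beyond the scatter) is beyond the scatter. Compound 3 `COc1cc2cc(Oc3ccc(NC(=O)Nc4ccc(Cl)c(C(F)(F)F)c4)cc3)c(C)nc2cc1OC` is not yet measured. Compound 3 differs from compound 2 by chloro in place of hydrogen on an aromatic carbon. For the measured compounds named here, no measured step covers this kind of change: the one step known concerns where the trifluoromethyl sits on the ring, not an added chloro. The expectation therefore rests only on compound 2 itself, with the step of a number 1.2 percentage points lower from compound 2 to compound 3 (within the scatter) expected to stay within the scatter. Compound 3 is estimated to give 10% in this assay, expected between 0% and 32%.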

Compound 3, a percentage reported as activity, at one concentration (the size of the read-out at that concentration, not a potency): 13.6%
Estimate against measurement, compound 3: 3.6 percentage points below; low and high end bracket the measured number.
By their numbers in this assay, from the lowest: compounds 2 and 3 (each within the scatter of the next); then compound 1.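

In this assay, the step of a number 2.4 percentage points higher from compound 2 to compound 3 (within the scatter) shows that chloro can take the place of hydrogen on this aromatic carbon, ortho to a trifluoromethyl group and para to a large group, without a change beyond the scatter, something the earlier pair could not show, since it only moved the trifluoromethyl group. The large gap to the 4-(trifluoromethyl)phenyl compound also survives the added chloro, as a number 42.5 percentage points lower from compound 1 to compound 3 (beyond the scatter) shows for this one pair. Nothing available here explains why the added chloro leaves the read-out so little moved.

Still open, going by these compounds, is whether a larger or different group in this place, such as a methoxy group or an amine, would hold the effect as chloro does. A single tested concentration also leaves open whether compound 2 and compound 3 would separate at lower concentrations.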